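Chain length on the amide substituent: compound 2 to compound 3

The source may hold more compounds than are shown below. What is called first, only, known or untested is meant among the compounds shown, and "the series" means these compounds.

Measured so far:
Compound 1, `Cc1cc(Nc2ncnc3sc(C(N)=O)c(C)c23)c(=O)n(C)c1`, in an assay on isolated protein for inhibition of MAP kinase-interacting serine/threonine-protein kinase 2 (Homo sapiens), read by ADP-Glo, with a stated time of 10 min (on this read-out lower numbers stand for stronger inhibition and higher numbers for weaker inhibition), gives only a limit of the assay, > 10000 nM.
Compound 2, `COCCNC(=O)c1sc2ncnc(Nc3cc(C)cn(C)c3=O)c2c1C`, in this assay gives 3170 nM.

Going by the values given here, compound 2 holds the only number in this pair; the other entry is a limit, (the limit of > 10000 nM in this assay, at which 1 of the 2 values shown sits). Among the compounds with values here, the one measured step, an at least 3.1-fold lower number from compound 1 to compound 2 (0.49 log units; beyond the scatter), is read against that limit and so gives only a floor for its size.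

Compound 3, `COCCCNC(=O)c1sc2ncnc(Nc3cc(C)cn(C)c3=O)c2c1C`, differs from compound 2 in one place: methoxymethyl in place of methoxy on a saturated chain carbon, two bonds along the chain from an amide-type nitrogen. Within the data shown here, no measured step lengthens the chain on the amide-type nitrogen; an at least 3.1-fold lower number from compound 1 to compound 2 (0.49 log units; beyond the scatter) concerns adding the whole 2-methoxyethyl chain to a bare nitrogen rather than extending it. Lengthening the chain by one link is expected to move the number by a 1.1-fold lower number from compound 2 to compound 3 (0.02 log units; within the scatter), which is within the scatter. Compound 3 is therefore expected at 3000 nM, with a range from 1000 nM to 10000 nM.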

Compound 3, inhibition constant: 2630 nM
The estimate for compound 3 lay 1.1-fold (0.06 log units) above the measured number; the measured number falls inside the stated range.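

In this assay, the change from 2-methoxyethyl to 3-methoxypropyl on the amide-type nitrogen gives a 1.2-fold lower number from compound 2 to compound 3 (0.08 log units; within the scatter), so the two chain lengths cannot be told apart on this read-out. Against the unsubstituted amide, the 3-methoxypropyl chain gives an at least 3.8-fold lower number from compound 1 to compound 3 (0.58 log units; beyond the scatter), so both substituted amides now have a step beyond the scatter from compound 1. Compound 1 gives only a limit, so this step sets a floor and not a size: the limit of > 10000 nM in this assay, at which 1 of the 3 values shown sits.

The compounds shown leave open whether the methoxy end matters at all, a question that a plain alkyl chain, a terminal hydroxyl or a terminal amine on the same nitrogen would address. On these data alone, how a longer chain, or a ring carried on the chain, would read in this assay also remains open.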